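Solubility notes: 2-methylphenyl in place of 1H-indol-4-yl

The source may report more compounds than this note shows. Statements on the series, on what has been measured and on what is new or still open speak of the compounds shown alone.

Compound 3 `CNC(=O)c1cc(C(=O)N[C@H]2[C@@H]3COC[C@@H]32)cc2c1OC[C@H]2c1cccc2[nH]ccc12` carries 1H-indol-4-yl on a saturated ring carbon of the shared core. In a physicochemical assay for solubility (on this read-out lower numbers stand for lower solubility and higher numbers for higher solubility), compound 3 gives >= 171 ug/mL, which is a limit of the assay rather than a number. Its neighbours in the series are compound 1 `CNC(=O)c1cc(C(=O)N[C@H]2[C@@H]3COC[C@@H]32)cc2c1OC[C@H]2c1cccnc1` and compound 2 `CNC(=O)c1cc(C(=O)N[C@H]2[C@@H]3COC[C@@H]32)cc2c1OC[C@H]2c1ccccn1`. In this assay compound 1 gives >= 104 ug/mL, again a limit. In this assay compound 2 gives >= 158 ug/mL, also a limit. The steps a step that the two limits leave unreadable from compound 1 to compound 2, a step that the two limits leave unreadable from compound 1 to compound 3 and a step that the two limits leave unreadable from compound 2 to compound 3 thus have no readable size, and compound 3 stands as one of three limits, at the limit of >= 171 ug/mL in this assay, at which 1 of the 3 values shown sits.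

Compound 4 `CNC(=O)c1cc(C(=O)N[C@H]2[C@@H]3COC[C@@H]32)cc2c1OC[C@H]2c1ccccc1C` differs from compound 3 by 2-methylphenyl in place of 1H-indol-4-yl on a saturated ring carbon. For the measured compounds named here, no measured step bears on this change with a readable size; the three values only show that every aryl group tried so far came out as a limit. For compound 4 a step of an at least 2.8-fold lower number from compound 3 to compound 4 (0.45 log units; beyond the scatter) toward lower solubility is expected, with a wide range. The estimate for compound 4 in this assay is 60 ug/mL, between 20 ug/mL and 180 ug/mL.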

Compound 4, solubility: >= 103 ug/mL
Compound 4 was reported as a limit; the forecaster's own chance of this, stated with the estimate: 35%; at least 1.7-fold (0.23 log units) between middle value and limit.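

In this assay compound 4 gives >= 103 ug/mL, which is a limit of the assay. For the compounds shown here, compound 1, compound 2 and compound 3 are limits too, so no step to compound 4 can be read. The compounds shown leave open whether these four groups differ at all in this assay.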